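The source may report more compounds than this note shows. Statements on the series, on what has been measured and on what is new or still open speak of the compounds shown alone.

Measured so far in an ADME assay, in phosphate buffer, at 28 degrees C, at pH 7.0; a higher number here means that the compound lasts longer, a lower number that the compound disappears faster:
compound 1, `CC(C)(C)C1=C(C(=O)O)N2C(=O)[C@H](CO)[C@H]2O1`, 5 h;
compound 2, `C[C@@H](O)[C@H]1C(=O)N2C(C(=O)O)=C(C(C)(C)C)O[C@H]12`, 8.1 h;
compound 3, `CC(C)(C)C1=C(C(=O)O)N2C(=O)[C@H](CNS(C)(=O)=O)[C@H]2O1`, 2.2 h.

Compound 3 gives the lowest of the three numbers: the steps of a 2.3-fold lower number from compound 1 to compound 3 (0.36 log units; beyond the scatter) and a 3.7-fold lower number from compound 2 to compound 3 (0.57 log units; beyond the scatter) both lie beyond the scatter, whereas the step of a 1.6-fold higher number from compound 1 to compound 2 (0.21 log units; within the scatter) does not. Compound 4, `CC(C)(C)C1=C(C(=O)O)N2C(=O)[C@H](CNS(=O)(=O)Cc3ccccc3)[C@H]2O1`, is not yet measured; it differs from compound 3 by phenyl in place of hydrogen on a saturated chain carbon bound to a sulfonyl sulfur. Among the measured compounds shown here, none of the measured steps touches this place: all three concern hydroxy, 1-hydroxyethyl or methanesulfonamido on the side chain, not the saturated chain carbon bound to the sulfonyl sulfur. The measured data therefore give no basis for a step in either direction beyond the scatter. Compound 4 is expected in this assay to give about 2 h, range 0.9 h to 4.5 h, an expected step of a 1.1-fold lower number from compound 3 to compound 4 (0.04 log units; within the scatter).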

Compound 4, half-life: 8.9 h
Beside the measured number, compound 4's estimate is 4.5-fold (0.65 log units) below it; measured number outside the range, above it.
By their numbers in this assay, from the lowest: compound 3; then compounds 1, 2 and 4 (each within the scatter of the next).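

In this assay the saturated chain carbon bound to a sulfonyl sulfur turns out to be a responsive place, with phenyl in place of hydrogen giving a 4.0-fold higher number from compound 3 to compound 4 (0.61 log units; beyond the scatter) on this change from methyl to benzyl. The earlier steps shown here replaced the whole side chain group and gave no reading at this carbon. No measurement shown bears on what lies behind this step.

The compounds shown leave open whether a saturated longer chain in place of the phenyl would give a similar number. On these data alone, how an amine or a carboxylic acid on the phenyl ring would read also remains open.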